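The source may hold more compounds than are shown below. What is called first, only, known or untested is meant among the compounds shown, and "the series" means these compounds.

Measured so far in a functional assay on MDA-MB-231 cells (Homo sapiens) for antiproliferative activity, read by XTT assay, with a stated time of 72 h; on this read-out lower numbers stand for stronger inhibition and higher numbers for weaker inhibition: compound 1 `COc1ccc(-c2cc3ccccc3nc2/C=C/C(=O)c2ccccc2)cc1` gives 860 nM; compound 2 `COc1ccc(-c2cc3ccccc3nc2/C=C/C(=O)c2ccc(O)cc2)cc1` gives 6350 nM; compound 3 `COc1ccc(-c2cc3ccccc3nc2/C=C/C(=O)c2c(OC)cccc2OC)cc1` gives 5630 nM.

Compound 3 stands second highest of the three numbers. Its nearest neighbour is compound 2, a step of a 1.1-fold lower number from compound 2 to compound 3 (0.05 log units; within the scatter); its furthest is compound 1, with a 6.5-fold higher number from compound 1 to compound 3 (0.82 log units; beyond the scatter). Compound 4 `COc1ccc(-c2cc3ccccc3nc2/C=C/C(=O)c2ccc([N+](=O)[O-])cc2)cc1` differs from compound 3 in one place: 4-nitrophenyl in place of 2,6-dimethoxyphenyl on a carbonyl carbon.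

Within the data shown here, two measured steps bear on the aryl group attached to the carbonyl carbon. Both changes away from the plain phenyl of compound 1 raised the number: a 7.4-fold higher number from compound 1 to compound 2 (0.87 log units; beyond the scatter) and a 6.5-fold higher number from compound 1 to compound 3 (0.82 log units; beyond the scatter). Between the two substituted variants themselves, the step of a 1.1-fold lower number from compound 2 to compound 3 (0.05 log units; within the scatter) was within the scatter. Among the measured compounds shown here, no compound with a nitro group has been measured, so the nitrophenyl itself is untested.

The expectation is therefore that compound 4 will stay within the scatter of compound 3 in this assay, with a step of a 1.4-fold lower number from compound 3 to compound 4 (0.15 log units; within the scatter), because compound 2 and compound 3 sit together after a 1.1-fold lower number from compound 2 to compound 3 (0.05 log units; within the scatter). Compound 4 is estimated at 4000 nM, between 1200 nM and 13000 nM.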

Compound 4, half-maximal inhibitory concentration: 840 nM
Beside the measured number, compound 4's estimate is 4.8-fold (0.68 log units) above it; measured number outside the range, below it.
By their numbers in this assay, from the lowest: compounds 4 and 1 (each within the scatter of the next); then compounds 3 and 2 (each within the scatter of the next).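

In this assay, the aryl group on the carbonyl carbon turns out to tolerate at least one substituent: nitro in place of hydrogen on an aromatic carbon gives a 1.0-fold lower number from compound 1 to compound 4 (0.01 log units; within the scatter). The 4-nitrophenyl in place of 2,6-dimethoxyphenyl gives a 6.7-fold lower number from compound 3 to compound 4 (0.83 log units; beyond the scatter), and nitro in place of hydroxy gives a 7.6-fold lower number from compound 2 to compound 4 (0.88 log units; beyond the scatter), so the losses seen earlier do not extend to every substituted ring, and the outcome at this position depends on which group the ring carries. Nothing measured here gives a reason for this difference.

The compounds shown leave open whether an amine, a carboxylic acid or a fluorine on this ring would fall with compound 1 and compound 4 or with compound 2 and compound 3. They also leave open whether any such group could give a lower number than the plain phenyl of compound 1 does.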